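Cytotoxicity notes: piperazine in place of methanesulfonamido-piperidine

The compounds below may be only part of what the source reports. "The series", "measured", "known", "first", "only" and "open" are said of these compounds alone.

Compound 3 `Cc1cc(/C=C/C#N)cc(C)c1Oc1nc(Nc2ccc(N3CCCC(NS(C)(=O)=O)C3)cc2)nc2ccsc12` is run in an ADME assay on MT4 cells (Homo sapiens) for cytotoxicity, read by MTT assay, with a stated time of 5 days; a lower number here means that less compound is tolerated, a higher number that more compound is tolerated. In this assay compound 3 gives > 217000 nM, which is a limit of the assay and not a number. Compound 2 `Cc1cc(/C=C/C#N)cc(C)c1Oc1nc(Nc2ccc(N3CCCC(NS(N)(=O)=O)C3)cc2)nc2ccsc12` returns the same kind of limit, > 217000 nM. Going by the values given here, compound 1 `Cc1cc(/C=C/C#N)cc(C)c1Oc1nc(Nc2ccc(CN3CCN(S(N)(=O)=O)CC3)cc2)nc2ccsc12` is the only member with a number in this assay, 145000 nM. The steps out of compound 1 run an at least 1.4-fold higher number from compound 1 to compound 2 (0.17 log units; that floor lies within the scatter) and an at least 1.4-fold higher number from compound 1 to compound 3 (0.17 log units; that floor lies within the scatter), and between the two limits the step is a step that the two limits leave unreadable from compound 2 to compound 3. Compound 3 therefore stands at the limit of > 217000 nM in this assay, at which 2 of the 3 values shown sit, with no readable number of its own.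

Compound 4 `Cc1cc(/C=C/C#N)cc(C)c1Oc1nc(Nc2ccc(N3CCNCC3)cc2)nc2ccsc12` differs from compound 3 by piperazin-1-yl in place of 3-(methanesulfonamido)piperidin-1-yl on an aromatic carbon. Among the compounds with values here, none of the measured steps alters the ring attached to the aromatic carbon in this way; the steps that are known either sit within the scatter or cannot be read. The expected step from compound 3 to compound 4 in this assay is an at least 1.2-fold lower number from compound 3 to compound 4 (0.08 log units; that floor lies within the scatter), nothing beyond the scatter. Compound 4 is expected to give about 180000 nM in this assay, between 90000 nM and 300000 nM, with a real chance that only a limit is reported.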

Compound 4, half-maximal cytotoxic concentration: 5730 nM
For compound 4 the middle estimate is 31-fold (1.50 log units) above the measured one; the measured number lies below the stated range.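

Placing piperazin-1-yl on the aromatic carbon para to a large group gives an at least 37-fold lower number from compound 3 to compound 4 (1.57 log units; beyond the scatter), an at least 37-fold lower number from compound 2 to compound 4 (1.57 log units; beyond the scatter) and a 25-fold lower number from compound 1 to compound 4 (1.40 log units; beyond the scatter), all in this assay. Going by these compounds alone, the earlier steps at this place lay within the scatter or could not be read, so this is the first sign that the group on this carbon can move the number by a large amount, and compound 4 is the only one of the four whose group carries no sulfonyl. The first two of these steps are floors and not sizes: the limit of > 217000 nM in this assay, at which 2 of the 4 values shown sit.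

The compounds shown do not separate the loss of the sulfonyl-bearing substituent from the change of ring. From the compounds shown here alone, whether a plain piperidin-1-yl or a 4-acetylpiperazin-1-yl on this carbon would read close to compound 4 remains open.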